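Oxime geometry at the cyano analogue of the series

This account rests on a few compounds, and the source may have more. Where it says the series, first, only, none or still open, it means among the compounds named here.

Measured so far in a functional assay on HEK293 cells with D(4) dopamine receptor (Homo sapiens) as the target, read by FLIPR; on this read-out higher numbers stand for larger maximal responses and lower numbers for smaller maximal responses:
compound 1 `O/N=C(\CCN1CCN(c2ccccn2)CC1)c1ccccc1`: 70%
compound 2 `O/N=C(/CCN1CCN(c2ccccn2)CC1)c1ccccc1`: 74%
compound 3 `N#Cc1cccnc1N1CCN(CC/C(=N\O)c2ccccc2)CC1`: 64%

Compound 3 stands lowest of the three numbers in this assay, though the step of a number 6 percentage points lower from compound 1 to compound 3 (within the scatter) lies within the scatter, and the value of compound 2 74% also lies within the scatter of the value of compound 3 64%; none of the three is separated from the others beyond the scatter.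

Compound 4 `N#Cc1cccnc1N1CCN(CC/C(=N/O)c2ccccc2)CC1` has not yet been measured. It differs from compound 3 as follows: the two compounds have the same atoms and bonds and differ only in configuration as drawn: 1 of 1 stereo elements differ; a double bond is drawn E in compound 3 and Z in compound 4

Going by the values given here, one measured step bears directly on this change: a number 4 percentage points higher from compound 1 to compound 2 (within the scatter). That pair differs only in the configuration as drawn (the fact that compounds 1 and 2 differ only in the configuration as drawn), and the step stayed within the scatter. The step of a number 6 percentage points lower from compound 1 to compound 3 (within the scatter) concerns the cyano group and not the geometry, so it gives no further guidance here. On this basis no step beyond the scatter is expected from compound 3 to compound 4 in this assay; at most a small upward movement of the size seen between compound 1 and compound 2.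

The efficacy of compound 4 in this assay is therefore estimated at 68%, with a range from 56% to 80%, which means an expected step of a number 4 percentage points higher from compound 3 to compound 4 (within the scatter).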

Compound 4, largest response reached (reported as efficacy), in percent of the reference or control that the assay uses: 49%
For compound 4 the middle estimate is 19 percentage points above the measured one; measured number below the stated range.
By their numbers in this assay, from the lowest: compound 4; then compounds 3, 1 and 2 (each within the scatter of the next).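

Working notes: in this assay, oxime geometry is not a neutral change on every core: moving the double bond from E to Z on the cyano-bearing core gives a number 15 percentage points lower from compound 3 to compound 4 (beyond the scatter), whereas the same change without the cyano group gave only a number 4 percentage points higher from compound 1 to compound 2 (within the scatter). Going by these compounds alone, the cyano group in turn depends on the geometry it is paired with, since in the Z pair it gives a number 25 percentage points lower from compound 2 to compound 4 (beyond the scatter), and the comparison with the E pair is the clearest finding of the series so far: the same change on two cores in this assay, a number 6 percentage points lower (within the scatter) from compound 1 to compound 3 and a number 25 percentage points lower (beyond the scatter) from compound 2 to compound 4, 19 percentage points apart, beyond the scatter of two such steps. Across these four compounds, the two changes therefore do not add up independently in maximal response, so a step read on one core cannot simply be carried over to the other, although this rests on a single set of paired compounds.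

On these data alone, whether a chloro or methoxy group in place of the cyano group would show the same dependence on oxime geometry stays open. Also open, as far as these compounds go, is whether a methyl ether of the oxime, on either core, would keep the gap between the E and Z forms.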